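Replacing Isopropylcarbonyl with 2,4-Dinitrophenyl on an Amine Nitrogen

The source may hold more compounds than are shown below. What is called first, only, known or untested is meant among the compounds shown, and "the series" means these compounds.

Measured compounds in a toxicity assay on KB cells (Homo sapiens) for cytotoxicity, read by fluorescence, with a stated time of 3 days; on this read-out higher numbers stand for an effect only at larger amounts of compound and lower numbers for an effect already at smaller amounts:
compound 1 `CCCCOC(=O)CNC(=O)[C@H](CSc1ccc([N+](=O)[O-])cc1[N+](=O)[O-])NC(=O)CC[C@H](NC(=O)CCC(C)C)C(=O)OCCCC`: 84 uM
compound 2 `CCCCOC(=O)CNC(=O)[C@H](CSc1ccc([N+](=O)[O-])cc1[N+](=O)[O-])NC(=O)CC[C@H](NC(=O)OC(C)(C)C)C(=O)OCCCC`: 70.4 uM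
compound 3 `CCCCOC(=O)CNC(=O)[C@H](CSc1ccc([N+](=O)[O-])cc1[N+](=O)[O-])NC(=O)CC[C@H](NC(=O)C(C)C)C(=O)OCCCC`: > 300 uM

Compound 3 stands at the limit of > 300 uM in this assay, at which 1 of the 3 values shown sits. Going by these compounds, this is a limit and not a number, so its true position on the scale is unknown.

The next compound to be tested is compound 4 `CCCCOC(=O)CNC(=O)[C@H](CSc1ccc([N+](=O)[O-])cc1[N+](=O)[O-])NC(=O)CC[C@H](Nc1ccc([N+](=O)[O-])cc1[N+](=O)[O-])C(=O)OCCCC`. Its change from compound 3 is 2,4-dinitrophenyl in place of isopropylcarbonyl on an amine nitrogen. The whole isopropylcarbonyl group goes, so the nitrogen no longer carries a carbonyl at all.

Going by the values given here, three measured steps bear on this, since all of them alter the same substituent. Two start from other groups and end at isopropyl: an at least 3.5-fold higher number from compound 1 to compound 3 (0.55 log units; beyond the scatter), and an at least 4.2-fold higher number from compound 2 to compound 3 (0.62 log units; beyond the scatter). The third, a 1.2-fold lower number from compound 1 to compound 2 (0.08 log units; within the scatter), shows that the isopentyl and tert-butoxy groups cannot be told apart here. None of these steps introduces 2,4-dinitrophenyl, so they offer only a loose guide.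

Of the three groups tested, only isopropyl reaches the limit. Leaving it is therefore expected to bring a step of modest size or more towards a lower number in this assay, landing near compound 1 at 84 uM. The estimated change is an at least 3.7-fold lower number from compound 3 to compound 4 (0.57 log units; beyond the scatter). For compound 4 the estimate is 80 uM, with an expected range from 25 uM to 250 uM.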

Compound 4, concentration for half-maximal effect: > 300 uM
Compound 4: only a limit was reported (the forecaster's own chance of this, stated with the estimate: 20%); middle value at least 3.7-fold (0.57 log units) away from the limit.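

In this assay compound 4 gives > 300 uM, which is a limit and not a number, so a second group on this amine nitrogen now ends at the limit: the limit of > 300 uM in this assay, at which 2 of the 4 values shown sit.

The readable steps are an at least 4.2-fold higher number from compound 2 to compound 4 (0.62 log units; beyond the scatter) and an at least 3.5-fold higher number from compound 1 to compound 4 (0.55 log units; beyond the scatter). On this nitrogen, then, a group with no carbonyl at all separates from the tert-butoxycarbonyl and isopentylcarbonyl groups, as isopropylcarbonyl already did, so keeping a carbonyl at this place is not what decides the outcome among the compounds shown. Compound 3 and compound 4 both end in limits, so the step between them cannot be read and the two groups cannot be put in order.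

Going by these compounds, what sets isopropylcarbonyl and 2,4-dinitrophenyl apart from the two groups with readable values remains open, and these four compounds offer no single feature that sorts them. On these data alone, how a free amine, an acetyl group or a longer acyl chain on this nitrogen would stand in this assay is also open.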